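A second chloro group on compound 2

The source may report more compounds than this note shows. Statements on the series, on what has been measured and on what is new or still open speak of the compounds shown alone.

Compound 1 `OCc1cn(Cc2cccc(Cl)c2)c2ccccc12` gives 160 nM
Compound 2 `OCc1cn(Cc2ccc(Cl)cc2)c2ccccc12` gives 79 nM
Compound 3 `COc1ccc(Cn2cc(CO)c3ccccc32)cc1` gives 63 nM

All three were read in a functional assay on T29Kt1 cells (Homo sapiens) for cytotoxicity, read by sulforhodamine B assay, with a stated time of 3 days; on this read-out lower numbers stand for stronger inhibition and higher numbers for weaker inhibition. Compound 2 stands level with compound 3 within the scatter, while compound 1 shows a higher number than both. Compound 4 `OCc1cn(Cc2ccc(Cl)c(Cl)c2)c2ccccc12` has not yet been measured. It differs from compound 2 by one change, (chloro in place of hydrogen on an aromatic carbon), which puts chloro in place of hydrogen on an aromatic carbon, ortho to a chloro group. Going by the values given here, only one measured step bears on the same ring: a 1.3-fold lower number from compound 2 to compound 3 (0.10 log units; within the scatter), with methoxy in place of chloro. That is a different change, so it offers only loose guidance. Among the compounds with values here, the new chloro group also takes the place of the single chloro group in compound 1, which reads 160 nM, so a slight shift towards a higher number is conceivable. The expected change is small and stays within the scatter: a 1.1-fold higher number from compound 2 to compound 4 (0.06 log units; within the scatter). For compound 4 the estimated value is 90 nM, with an expected range from 40 nM to 200 nM.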

Compound 4, half-maximal inhibitory concentration: 310 nM
Beside the measured number, compound 4's estimate is 3.4-fold (0.54 log units) below it, and the stated range ends below it.
By their numbers in this assay, from the lowest: compounds 3 and 2 (each within the scatter of the next); then compounds 1 and 4 (each within the scatter of the next).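

In this assay, a chloro group placed ortho to the chloro group already present is not neutral on this ring: the step is a 3.9-fold higher number from compound 2 to compound 4 (0.59 log units; beyond the scatter), modest but beyond the scatter, whereas the earlier swap of methoxy for chloro stayed within it. Reached from the other single-chloro compound, the same kind of change gives a 1.9-fold higher number from compound 1 to compound 4 (0.29 log units; within the scatter), which lies within the scatter, so compound 4 stands level with compound 1 and apart from compound 2. No supporting evidence accounts for the different outcomes of these two steps.

On these data alone, whether a fluoro group, an amine or a carboxylic acid on this same aromatic carbon would read like the chloro group stays open. So does whether a chloro group added to compound 3 would give a step of similar size.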